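Swapping an Iodobenzyl Thioether for a Cyanobenzyl Thioether

The compounds below may be only part of what the source reports. "The series", "measured", "known", "first", "only" and "open" are said of these compounds alone.

Compound 2 `OC[C@H]1O[C@@H](n2cnc3c(SCc4ccccc4I)ncnc32)[C@H](O)[C@@H]1O` and compound 1 `OC[C@H]1O[C@@H](n2cnc3c(SCc4ccccc4Br)ncnc32)[C@H](O)[C@@H]1O` share one core and differ only in which halogen sits on the aromatic carbon. In an assay on isolated protein for inhibition of Equilibrative nucleoside transporter 1 (Homo sapiens) (on this read-out higher numbers stand for weaker inhibition and lower numbers for stronger inhibition), compound 1 gives 151 nM, while compound 2 gives 19.5 nM. The step of a 7.7-fold lower number from compound 1 to compound 2 (0.89 log units; beyond the scatter) lies beyond the scatter, so compound 2 stands as the stronger inhibitor of the two numbers in hand. Compound 3 `N#Cc1cccc(CSc2ncnc3c2ncn3[C@@H]2O[C@H](CO)[C@@H](O)[C@H]2O)c1` takes a different turn: 3-cyanophenyl in place of 2-iodophenyl on a saturated chain carbon bound to a sulfur. For the measured compounds named here, no measured step matches this change; the only step available, a 7.7-fold lower number from compound 1 to compound 2 (0.89 log units; beyond the scatter), exchanges one halogen for another and cannot say what replacing a halogen with a nitrile does. Without a comparable precedent, the expectation is a weaker number, with a broad range to reflect the uncertainty. For compound 3 the expected step of a 7.7-fold higher number from compound 2 to compound 3 (0.89 log units; beyond the scatter) points toward weaker inhibition in this assay. Compound 3 is therefore estimated at 150 nM, with a range from 30 nM to 800 nM.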

Compound 3, inhibition constant: 36.3 nM
Compound 3: middle estimate off by 4.1-fold (0.62 log units), on the high side; the measured number falls inside the stated range.
By their numbers in this assay, from the lowest: compounds 2 and 3 (each within the scatter of the next); then compound 1.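

In this assay, the position on a saturated chain carbon bound to a sulfur tolerates a ring without a halogen: the change from 2-iodophenyl to 3-cyanophenyl gives a 1.9-fold higher number from compound 2 to compound 3 (0.27 log units; within the scatter) and so leaves the two compounds indistinguishable, even though the entering group carries a triple bond and a hydrogen-bond acceptor that the leaving group lacks. Against the bromo analogue, the same 3-cyanophenyl group gives a 4.2-fold lower number from compound 1 to compound 3 (0.62 log units; beyond the scatter) and this gap is a real one, so among these three compounds a halogen on the ring is not required for the lower numbers. Nothing in the data explains why these groups give the numbers they do.

The names 2-iodophenyl and 3-cyanophenyl differ in both the group and its number on the ring, so this step cannot separate the effect of swapping iodine for a nitrile from the effect of moving the substituent, and 2-cyanophenyl and 3-iodophenyl would be needed to pull the two apart. From the compounds shown here alone, whether the position also accepts a ring bearing an amine or a carboxylic acid remains open.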